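Ethyl for methyl on the sulfonyl group

A few compounds are considered here, and "the series" means these few. Any claim that something is new, unique, unknown or untested is made for them only; others in the source may bear on it.

Measured compounds:
- compound 1, `CCS(=O)(=O)c1ccc(COC[C@@H]2C[C@@H]2C2CCN(c3nc(C(C)C)no3)CC2)c(F)c1`: 0.8 nM
- compound 2, `COCc1cnc(N2CCC([C@H]3C[C@H]3COCc3ccc(S(C)(=O)=O)cc3F)CC2)nc1`: 2.1 nM

Two compounds carry numbers in a functional assay on CHO cells for agonist activity at Glucose-dependent insulinotropic receptor (Homo sapiens), read by cAMP accumulation (a lower number here means that less compound is needed, a higher number that more compound is needed for the effect), so far. Compound 2 gives 2.1 nM, the higher of the two; compound 1, the nearer and only other point, gives 0.8 nM, a gap beyond the scatter. Compound 1 differs from compound 2 at both ends of the molecule, so the two values do not isolate any single change.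

Compound 3, `CCS(=O)(=O)c1ccc(COC[C@@H]2C[C@@H]2C2CCN(c3ncc(COC)cn3)CC2)c(F)c1`, is not yet measured. It keeps the whole of compound 2 except for one change: methyl in place of hydrogen on a saturated chain carbon bound to a sulfonyl sulfur. Going by the values given here, no measured pair separates this change on its own. Among the compounds with values here, the only measured compound carrying ethylsulfonyl is compound 1, and its value also reflects a different heteroaryl on the piperidine nitrogen, so it cannot be read as a step.

With nothing isolating the change, the expectation for compound 3 is a small step from compound 2, if any, within the scatter, perhaps toward a slightly lower number: compound 3 is estimated at 1.6 nM, range 0.7 nM to 3.5 nM. The expected step from compound 2 to compound 3 is a 1.3-fold lower number from compound 2 to compound 3 (0.12 log units; within the scatter).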

Compound 3, half-maximal effective concentration in the Glucose-dependent insulinotropic receptor assay: 7.1 nM
Estimate against measurement, compound 3: 4.4-fold (0.65 log units) below; measured number outside the range, above it.
By their numbers in the Glucose-dependent insulinotropic receptor assay, from the lowest: compound 1; then compound 2; then compound 3.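

In the Glucose-dependent insulinotropic receptor assay, the chain on the sulfonyl sulfur is not a neutral place to build on: methyl in place of hydrogen on the saturated chain carbon bound to the sulfonyl sulfur gives a 3.4-fold higher number from compound 2 to compound 3 (0.53 log units; beyond the scatter) with the 5-(methoxymethyl)pyrimidin-2-yl group held constant, compound 2 giving 2.1 nM and compound 3 giving 7.1 nM. With ethylsulfonyl now held constant in turn, the same assay, the Glucose-dependent insulinotropic receptor assay, shows 5-(methoxymethyl)pyrimidin-2-yl in place of 3-isopropyl-1,2,4-oxadiazol-5-yl as an 8.9-fold higher number from compound 1 to compound 3 (0.95 log units; beyond the scatter) and so shows that ethylsulfonyl alone does not carry the low number of compound 1, which now traces to the group on the ring amine nitrogen. In a physicochemical assay for lipophilicity, read by HPLC, at pH 7 (a lower number here means a more polar compound, a higher number a more lipophilic compound), compound 2 gives 3.5 and compound 3 gives 3.8; the methyl-to-ethyl change reads as a number 0.30 log units higher from compound 2 to compound 3 (within the scatter) and nothing available accounts for either step in the series.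

Open, as far as these compounds go, is whether the ethyl penalty seen with the 5-(methoxymethyl)pyrimidin-2-yl group also holds with the 3-isopropyl-1,2,4-oxadiazol-5-yl group, as these compounds give no methylsulfonyl partner for compound 1. Also open, from the compounds shown here alone, is how the trend continues along the sulfonyl substituent, for example with a longer chain such as propyl, a branched isopropyl or a cyclopropyl ring.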